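Swapping a Nitrophenyl for a Methoxyphenyl: An Expected Outcome

The compounds below may be only part of what the source reports. "The series", "measured", "known", "first", "only" and "open" are said of these compounds alone.

Three compounds have been measured in a functional assay on HEp-2 cells (Homo sapiens) for cytotoxicity, read by sulforhodamine B assay, with a stated time of 48 h; a lower number here means a stronger inhibitor, a higher number a weaker inhibitor:
compound 1 `CC(=O)N1N=C(c2ccco2)CC1c1ccccc1[N+](=O)[O-]` gives 47900 nM
compound 2 `COc1cc(OC)c(C2CC(c3ccco3)=NN2C(C)=O)cc1OC` gives 6690 nM
compound 3 `O=CCN1N=C(c2ccc3ccccc3c2)CC1c1ccccc1[N+](=O)[O-]` gives 3630 nM

Compound 3 has the lowest number of the three in this assay. Its gap to compound 2 lies within the usual scatter, so the two cannot be told apart. Its gap to compound 1 lies well beyond the scatter, so compound 3 is clearly a stronger inhibitor than compound 1.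

Compound 4 `COc1ccc(C2CC(c3ccc4ccccc4c3)=NN2CC=O)cc1` has not yet been measured. It differs from compound 3 in one place: 4-methoxyphenyl in place of 2-nitrophenyl on a saturated ring carbon. Within the data shown here, no directly comparable pair among the measured compounds shows this exact exchange, so its effect is not known from these data. Compound 2, which carries a methoxy-bearing phenyl, and compound 1, which carries the 2-nitrophenyl, differ in other places as well, so they give only a loose hint.

The step from compound 3 to compound 4 is therefore expected to be small, at most a modest move toward stronger inhibition, as a 1.5-fold lower number from compound 3 to compound 4 (0.16 log units; within the scatter). Compound 4 is estimated at 2500 nM, with a range from 800 nM to 8000 nM.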

Compound 4, half-maximal inhibitory concentration: 3230 nM
Beside the measured number, compound 4's estimate is 1.3-fold (0.11 log units) below it; measured number inside the range.
By their numbers in this assay, from the lowest: compounds 4, 3 and 2 (each within the scatter of the next, the first and the last beyond it); then compound 1.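

In this assay, the exchange of 2-nitrophenyl for 4-methoxyphenyl on a saturated ring carbon gives a 1.1-fold lower number from compound 3 to compound 4 (0.05 log units; within the scatter), so the two compounds cannot be told apart. This is the first pair shown that isolates this position, and it shows that two quite different phenyl groups, one with a nitro group and one with a methoxy group, read alike here on this core, whereas the earlier compounds differed in more than one place and gave only a loose hint. No measurement at hand explains why the exchange leaves the reading unresolved, and the pair does not show which feature of either group matters, if any does.

Because the two groups differ in both substituent and ring placement, this single pair cannot separate those two changes, so 2-methoxyphenyl and 4-nitrophenyl would be the informative partners. As far as these compounds go, it also remains open whether this position keeps the same reading with a group of another kind, such as an amine or a carboxylic acid on the phenyl ring, or a longer chain in place of the ring.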